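The source may hold more compounds than are shown below. What is called first, only, known or untested is meant among the compounds shown, and "the series" means these compounds.

Among the compounds with values here, in an ADME assay on Huh-5-2 cells (Homo sapiens) for cytotoxicity (a higher number here means that more compound is tolerated, a lower number that less compound is tolerated), compound 2 `NC(=O)c1nc(C#Cc2ccc(C(F)(F)F)cc2)n(COCCO)n1` gives 20 ug/mL, the only plain number among the two compounds measured. Compound 1 `NC(=O)c1nc(C#Cc2ccccc2)n(COCCO)n1` sits at a limit of this assay: compound 1 gives > 50 ug/mL, which marks a limit rather than a measured number. Within the data shown here, the one measured step runs an at least 2.5-fold lower number from compound 1 to compound 2 (0.39 log units; beyond the scatter), a change in which trifluoromethyl took the place of hydrogen on an aromatic carbon, so the tolerated amount fell beyond the scatter.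

Compound 3 `NC(=O)c1nc(C#Cc2ccc(F)cc2)n(COCCO)n1` differs from compound 2 by fluoro in place of trifluoromethyl on an aromatic carbon. This change undoes part of the measured step, since trifluoromethyl leaves and a single fluoro enters at the same position. The expectation is therefore a modest rise in this assay, though not necessarily all the way back to the limit where compound 1 sits. Compound 3 is expected to give about 35 ug/mL, with a likely range from 18 ug/mL to 70 ug/mL. That estimate amounts to an expected 1.8-fold higher number from compound 2 to compound 3 (0.24 log units; within the scatter).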

Compound 3, half-maximal cytotoxic concentration: > 50 ug/mL
Compound 3: no number, only a limit; the forecaster's own chance of this, stated with the estimate: 35%; middle value at least 1.4-fold (0.15 log units) from the limit.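

On the six-membered aromatic ring of carbon only, at the place para to a large group, fluoro in place of trifluoromethyl gives an at least 2.5-fold higher number from compound 2 to compound 3 (0.39 log units; beyond the scatter) in this assay. This shows that the drop seen with trifluoromethyl does not follow from every replacement of hydrogen at this position: of the two groups tested here, only trifluoromethyl brings the value down to a plain number. Whether fluoro differs from hydrogen at all cannot be read, because compound 1 and compound 3 both give only a limit: the limit of > 50 ug/mL in this assay, at which 2 of the 3 values shown sit.

On these data alone, how much of compound 1 or compound 3 the cells actually tolerate remains open. So does whether a chloro, a methyl or a nitrile at this position would behave like fluoro or like trifluoromethyl.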